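Swapping pentyl for phenyl on compound 2

The source may hold more compounds than are shown below. What is called first, only, known or untested is meant among the compounds shown, and "the series" means these compounds.

- Compound 1 `C/C(=N\C#N)N(Cc1ccccc1)Cc1ccc(Cl)nc1`: 2.11
- Compound 2 `CCCCC/C(=N\C#N)N(C)Cc1ccc(Cl)nc1`: 2.3
- Compound 3 `CCCN(Cc1ccc(Cl)nc1)/C(C)=N/C#N`: 1.62

In a physicochemical assay for lipophilicity, read by HPLC, using the shake flask method (a lower number here means a more polar compound, a higher number a more lipophilic compound), compound 2 gives 2.3, within the scatter of compound 1 and clearly above compound 3. Compound 4 `CN(Cc1ccc(Cl)nc1)/C(=N/C#N)c1ccccc1` alters one group of compound 2: phenyl in place of pentyl on a carbon with a double bond to nitrogen. Among the measured compounds shown here, no measured step makes this exact swap. The closest is a number 0.49 log units lower from compound 1 to compound 3 (beyond the scatter), where ethyl replaces phenyl at another place, on a saturated chain carbon bound to an amine nitrogen. That modest step offers only a rough size, so the direction here remains a judgement. A modest drop is expected, with an estimated step of a number 0.45 log units lower from compound 2 to compound 4 (beyond the scatter). In this assay, compound 4 is estimated at 1.85, within a range from 1.45 to 2.25.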

Compound 4, partition coefficient: 1.86
For compound 4 the middle estimate is 0.01 log units below the measured one; low and high end bracket the measured number.
By their numbers in this assay, from the lowest: compounds 3, 4, 1 and 2 (each within the scatter of the next, the first and the last beyond it).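

In this assay putting phenyl in place of pentyl on a carbon with a double bond to nitrogen gives a number 0.44 log units lower from compound 2 to compound 4 (beyond the scatter) and so shows that the number responds to a change at this position. Among the compounds shown here, the earlier step changed a different place, a saturated chain carbon bound to an amine nitrogen, so this is the first direct reading here. Nothing available explains the size of this step. The compounds shown leave open how an amine or a longer chain such as octyl would read on this carbon, and whether phenyl gives a similar step when the rest of the molecule differs.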